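A few compounds are considered here, and "the series" means these few. Any claim that something is new, unique, unknown or untested is made for them only; others in the source may bear on it.

Measured compounds:
Compound 1 `Cc1ccc(S(=O)(=O)N[C@@H](CC(=O)NC(C)(C)C)C(=O)NCCNC(=O)Nc2ccccc2)cc1`. In an ADME assay on Karpas-1106P cells (Homo sapiens) for cytotoxicity (on this read-out higher numbers stand for an effect only at larger amounts of compound and lower numbers for an effect already at smaller amounts), compound 1 gives > 11100 nM, a limit of the assay and not a number.
Compound 2 `COc1cccc(C(=O)NCCNC(=O)[C@H](CC(=O)NC(C)(C)C)NS(=O)(=O)c2ccc(C)cc2)c1`. In this assay compound 2 gives > 11100 nM, likewise only a limit.
Compound 3 `Cc1ccc(S(=O)(=O)N[C@@H](CC(=O)NC(C)(C)C)C(=O)NCCNC(=O)c2ccccc2Cl)cc1`. In this assay compound 3 gives > 11100 nM, again a limit.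

Compound 2 thus stands at the same limit as both other compounds; every value shown sits at the limit of > 11100 nM in this assay, at which 3 of the 3 values shown sit. The steps among them, a step that the two limits leave unreadable from compound 1 to compound 2, a step that the two limits leave unreadable from compound 1 to compound 3 and a step that the two limits leave unreadable from compound 2 to compound 3, cannot be read in size or direction, both ends being limits.

Compound 4 `C#Cc1cccc(C(=O)NCCNC(=O)[C@H](CC(=O)NC(C)(C)C)NS(=O)(=O)c2ccc(C)cc2)c1` is the next in line. It differs from compound 2 by ethynyl in place of methoxy on an aromatic carbon. The measured steps all exchange the group on the carbonyl carbon rather than a substituent on the aromatic ring, so none of them bears directly on this change, and none has a readable size in any case. No step beyond the scatter is therefore expected in this assay, in either direction. Compound 4 is expected to stay at the limit in this assay, the expected step being a step that the limit leaves unreadable from compound 2 to compound 4. The estimate for compound 4 is 20000 nM, with a range from 8000 nM to 60000 nM.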

Compound 4, half-maximal effective concentration: > 11100 nM
Compound 4 gave a limit, no number; the forecaster's own chance of this, stated with the estimate: 85%; the middle value lies beyond the limit too.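

No new step can be read from compound 4 to compound 1, compound 2 or compound 3 in this assay, since all four compounds end at one limit and not at a number: the limit of > 11100 nM in this assay, at which 4 of the 4 values shown sit.

The compounds shown leave open at what concentration any of them has an effect on these cells, and whether any change in the series alters it.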